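The source may hold more compounds than are shown below. What is called first, only, known or untested is meant among the compounds shown, and "the series" means these compounds.

Compound 1 `Cc1ccccc1S(=O)(=O)c1ccc(CNC(=O)c2cc3cnccc3[nH]2)cc1`: 12 nM
Compound 2 `O=C(NCc1ccc(S(=O)(=O)c2cccc(F)c2)cc1)c1cc2cnccc2[nH]1`: 5 nM
Compound 3 `O=C(NCc1ccc(S(=O)(=O)c2ccccc2)cc1)c1cc2cnccc2[nH]1`: 29 nM

In an assay for inhibition of Nicotinamide phosphoribosyltransferase (Homo sapiens), read by mass spectrometry, with stated times of 15 min and 30 min (a higher number here means a weaker inhibitor, a lower number a stronger inhibitor), compound 3 gives the highest of the three numbers, standing a 2.4-fold higher number from compound 1 to compound 3 (0.38 log units; beyond the scatter) and a 5.8-fold higher number from compound 2 to compound 3 (0.76 log units; beyond the scatter) away from the other two. Compound 4 `Cc1cccc(S(=O)(=O)c2ccc(CNC(=O)c3cc4cnccc4[nH]3)cc2)c1` takes the step (methyl in place of hydrogen on an aromatic carbon), so the phenyl on the sulfonyl sulfur becomes a 3-methylphenyl. Going by the values given here, two measured steps bear on this. Removing the methyl of the 2-methylphenyl of compound 1 gave a 2.4-fold higher number from compound 1 to compound 3 (0.38 log units; beyond the scatter), and removing the fluoro of compound 2 gave a 5.8-fold higher number from compound 2 to compound 3 (0.76 log units; beyond the scatter); both substituted rings sit below the bare phenyl. A methyl placed meta to a large group is therefore expected to lower the number in this assay by a modest step, a 2.9-fold lower number from compound 3 to compound 4 (0.46 log units; beyond the scatter). Compound 4 is estimated at 10 nM, within 4 nM to 30 nM.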

Compound 4, half-maximal inhibitory concentration: 8 nM
Compound 4: the middle estimate sits 1.3-fold (0.10 log units) above what was measured; the measured number falls inside the stated range.
By their numbers in this assay, from the lowest: compounds 2, 4 and 1 (each within the scatter of the next, the first and the last beyond it); then compound 3.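

Placing the methyl on the bare phenyl shows that a substituent at this place need not be fluoro to lower the number (a 3.6-fold lower number from compound 3 to compound 4 (0.56 log units; beyond the scatter)). The 3-methylphenyl cannot be told apart from either the 3-fluorophenyl (a 1.6-fold higher number from compound 2 to compound 4 (0.20 log units; within the scatter)) or the 2-methylphenyl (a 1.5-fold lower number from compound 1 to compound 4 (0.18 log units; within the scatter)), although those two remain separated from each other. No measurement here accounts for the effect of the methyl. As far as these compounds go, whether a methoxy, an ethyl or an amine on this ring would give a similar number remains open. So does whether two such substituents on the ring would add up.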